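The source may report more compounds than this note shows. Statements on the series, on what has been measured and on what is new or still open speak of the compounds shown alone.

Measured compounds:
compound 1, `CC(C)Oc1ccccc1OC(C)C1=NCCN1`: 1580 nM
compound 2, `Cc1cccc(C)c1OC(C)C1=NCCN1`: 182 nM
compound 3, `C=CCc1cccc(CC=C)c1OC(C)C1=NCCN1`: 275 nM

All three were tested in an assay on CHO cells for displacement of a labelled ligand from Alpha-2B adrenergic receptor (Homo sapiens); on this read-out higher numbers stand for weaker inhibition and lower numbers for stronger inhibition. Compound 1 stands at the highest number of the three, so on this read-out it is the weakest of the group. Compound 2 gives 182 nM and compound 3 gives 275 nM; each of these gaps to compound 1 is beyond the usual scatter of repeated measurements, so compound 1 is clearly apart from the other two. Compound 2 and compound 3 lie close enough to each other that nothing can be said about their order.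

Compound 4, `COc1ccccc1OC(C)C1=NCCN1`, has not yet been measured. It differs from compound 1 in one place: methyl in place of isopropyl on an oxygen on an aromatic ring. The shared core, the ring and the rest of the molecule stay as they are; only the group on the oxygen of the aromatic ring shrinks.

Among the compounds with values here, no measured pair shows what this change does on its own, so the expectation rests on compound 1 alone. A step of a 1.8-fold lower number from compound 1 to compound 4 (0.24 log units; within the scatter) is estimated, that is a modest move toward a lower number, though one that may well stay within the scatter. Compound 4 is expected to give about 900 nM in this assay, with a plausible range from 300 nM to 3000 nM.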

Compound 4, inhibition constant: 871 nM
Estimate against measurement, compound 4: 1.0-fold (0.01 log units) above; the range from low to high includes it.
By their numbers in this assay, from the lowest: compounds 2 and 3 (each within the scatter of the next); then compounds 4 and 1 (each within the scatter of the next).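

Replacing isopropyl with methyl on an oxygen on an aromatic ring gives a 1.8-fold lower number from compound 1 to compound 4 (0.26 log units; within the scatter) in this assay, so this single change, the first that can be read on its own here, does not separate the two compounds. At this place, then, a group of 3 carbon atoms and a group of 1 carbon atom give numbers that repeated measurements could not tell apart, and the data support no claim that either one is better. No other measurement bears on this result, so nothing can be said about what lies behind it.

Going by these compounds, what happens with other groups on this oxygen remains open: an ethyl group, a longer chain such as butyl, or a plain hydrogen, which would leave a free hydroxyl, could each give a number near these two or far from them. On these data alone, compounds 2 and 3 differ from compound 1 and compound 4 in more than one place, so how these ring groups relate to the group on the oxygen also stays open.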